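Demethylation of an aryl methoxy group in two urea series

The source may report more compounds than this note shows. Statements on the series, on what has been measured and on what is new or still open speak of the compounds shown alone.

Compound 1 `COc1cc(-c2nn(-c3cccc(NC(=O)Nc4cc(C(F)(F)F)cc(C(F)(F)F)c4)c3)cc2-c2ccncc2)ccc1Cl` carries a methoxy group on the phenyl ring that hangs from the shared core. In a functional assay on T47D cells (Homo sapiens) for inhibition, read by sulforhodamine B assay, with a stated time of 48 h (on this read-out higher numbers stand for weaker inhibition of growth and lower numbers for stronger inhibition of growth), compound 1 gives > 50000 nM, which is a limit of the assay rather than a number. Compound 2 `O=C(Nc1cccc(-n2cc(-c3ccncc3)c(-c3ccc(Cl)c(O)c3)n2)c1)Nc1cc(C(F)(F)F)cc(C(F)(F)F)c1` is its hydroxy counterpart, and in this assay compound 2 gives 14000 nM. The change between them, (hydrogen in place of methyl on an oxygen on an aromatic ring), brings an at least 3.5-fold lower number from compound 1 to compound 2 (0.55 log units; beyond the scatter); the step is known only as a bound because compound 1 sits at the limit of > 50000 nM in this assay, at which 1 of the 3 values shown sits.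

Compound 3 `COc1cc(-c2nn(-c3cccc(NC(=O)Nc4ccc(Cl)c(C(F)(F)F)c4)c3)cc2-c2ccncc2)ccc1Cl` keeps the methoxy group but carries a different urea end; the difference between the two cores is not broken down here. In this assay compound 3 gives > 32500 nM, again a limit and not a number, the one described as the limit of > 32500 nM in this assay, at which 1 of the 3 values shown sits. Compound 4 `O=C(Nc1cccc(-n2cc(-c3ccncc3)c(-c3ccc(Cl)c(O)c3)n2)c1)Nc1ccc(Cl)c(C(F)(F)F)c1` is the hydroxy analogue of compound 3, the change being (hydrogen in place of methyl on an oxygen on an aromatic ring), the same change as that from compound 1 to compound 2, made at a place described in identical words.

For the measured compounds named here, because the earlier step was an at least 3.5-fold lower number from compound 1 to compound 2 (0.55 log units; beyond the scatter), compound 4 is expected to show a step of about an at least 2.7-fold lower number from compound 3 to compound 4 (0.43 log units; beyond the scatter), though with only one precedent and two limits among three values the range is wide. Compound 4 is therefore estimated at 12000 nM, with plausible bounds of 4000 nM and 40000 nM.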

Compound 4, concentration for total growth inhibition: > 32500 nM
Compound 4 ended at the assay's limit; the forecaster's own chance of this, stated with the estimate: 30%; middle value at least 2.7-fold (0.43 log units) away from the limit.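

In this assay compound 4 gives > 32500 nM, a limit of the assay and not a number. Compound 3 sits at the same limit, so the step from compound 3 to compound 4 cannot be read: the limit of > 32500 nM in this assay, at which 2 of the 4 values shown sit. From the compounds shown here alone, what stays open is whether methoxy to hydroxy lowers the number with this urea end, as it does between compound 1 and compound 2.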